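Urea to Amide Swap on a Shared Core

The source may report more compounds than this note shows. Statements on the series, on what has been measured and on what is new or still open speak of the compounds shown alone.

Compound 1 `O=C(Nc1ccc(-n2ccc3nc(C(=O)NCc4ccccc4)ccc32)cc1)Nc1cccc(Cl)c1Cl` gives > 10000 nM in an ADME assay on HS27 cells (Homo sapiens) for cytotoxicity, read by MTT assay (a lower number here means a stronger inhibitor, a higher number a weaker inhibitor), which is a limit of the measurement rather than a number.
Compound 2 `NC(=O)c1ccc2c(ccn2-c2ccc(NC(=O)c3ccc(Cl)c(C(F)(F)F)c3)cc2)n1` gives > 10000 nM in this assay, again a limit.
Compound 3 `O=C(Nc1ccc(-n2ccc3nc(C(=O)NCc4ccccc4)ccc32)cc1)Nc1cccc(C(F)(F)F)c1` gives > 10000 nM in this assay, also a limit.

Compound 3 therefore stands at the same limit as the other two measured compounds, and all that the numbers say is summed up by the limit of > 10000 nM in this assay, at which 3 of the 3 values shown sit. Within the data shown here, the one step between measured compounds, a step that the two limits leave unreadable from compound 1 to compound 3, cannot be read because both ends are limits.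

Compound 4 `O=C(Nc1ccc(-n2ccc3nc(C(=O)NCc4ccccc4)ccc32)cc1)c1ccc(Cl)c(C(F)(F)F)c1` has not yet been measured. It differs from compound 3 by 4-chloro-3-(trifluoromethyl)phenyl in place of (3-(trifluoromethyl)phenyl)amino on a carbonyl carbon; the urea of compound 3 becomes an amide in compound 4. Among the measured compounds shown here, no measured step bears on this change directly, and the only step recorded, a step that the two limits leave unreadable from compound 1 to compound 3, is itself unreadable. For the measured compounds named here, with every value so far sitting at the limit, the expectation for compound 4 in this assay is simply that it stays there too, and the step that the limit leaves unreadable from compound 3 to compound 4 is estimated to be none beyond the scatter. Compound 4 is therefore expected to give 15000 nM, with a range from 8000 nM to 40000 nM, and most likely only another limit will be reported.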

Compound 4, half-maximal inhibitory concentration: 1500 nM
Beside the measured number, compound 4's estimate is 10-fold (1.00 log units) above it; the measured number lies below the stated range.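

In this assay, among these compounds, the group on the carbonyl carbon decides whether a number can be read at all: 4-chloro-3-(trifluoromethyl)phenyl in place of (3-(trifluoromethyl)phenyl)amino gives an at least 6.6-fold lower number from compound 3 to compound 4 (0.82 log units; beyond the scatter), and compound 4 holds the only readable number among the four. The urea with the 2,3-dichlorophenyl group tells the same story, with an at least 6.6-fold lower number from compound 1 to compound 4 (0.82 log units; beyond the scatter). The benzyl on the amide-type nitrogen counts as well, with an at least 6.6-fold lower number from compound 2 to compound 4 (0.82 log units; beyond the scatter), so among these compounds neither the benzyl alone nor the 4-chloro-3-(trifluoromethyl)phenyl amide alone brings the value off the limit, and only the two together do.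

The step between the two ureas, compound 1 and compound 3, cannot be read, and the true distance of the other compounds from compound 4 stays unknown, as each of them sits at a limit: the limit of > 10000 nM in this assay, at which 3 of the 4 values shown sit.

Still open, as far as these compounds go, is whether the lost nitrogen or the added chlorine carries the change, and how a methyl group or a longer chain such as phenethyl would read in place of the benzyl.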